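Permeability of compound 4: a hydroxymethoxybenzyl for furanylmethyl swap

The compounds below may be only part of what the source reports. "The series", "measured", "known", "first", "only" and "open" are said of these compounds alone.

Measured compounds:
compound 1 `COc1cccc(CNCCCNc2ccnc3cc(Cc4ccc(F)cc4)ccc23)c1O` – 23 10^-6 cm/s
compound 2 `COc1cccc(CNCCCNc2ccnc3cc(-c4ccc(F)cc4)ccc23)c1O` – 237 10^-6 cm/s
compound 3 `c1coc(CNCCCNc2ccnc3cc(C4CCCCC4)ccc23)c1` – 23 10^-6 cm/s

In an ADME assay for permeability, using PAMPA, with a stated time of 30 min, at pH 7.4 (a lower number here means that the compound crosses the layer more slowly, a higher number that the compound crosses the layer faster), compound 3 stands level with compound 1 at the digits given, the two together the lowest of the three numbers. Its furthest neighbour is compound 2: a 10-fold higher number from compound 1 to compound 2 (1.01 log units; beyond the scatter), a change at the aromatic carbon, not at the amine-bearing chain.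

Compound 4 `COc1cccc(CNCCCNc2ccnc3cc(C4CCCCC4)ccc23)c1O` has not been measured in this assay. It differs from compound 3 in one place: 2-hydroxy-3-methoxyphenyl in place of furan-2-yl on a saturated chain carbon bound to an amine nitrogen. Within the data shown here, no measured step touches this part of the molecule; the only step on record, a 10-fold higher number from compound 1 to compound 2 (1.01 log units; beyond the scatter), changes a different position and so does not carry over. What can be said is that compound 1 and compound 3, which already differ in exactly this group as well as at the aromatic carbon, give numbers within the scatter of each other.

Compound 4 is therefore expected near compound 3, at an estimated 30 10^-6 cm/s with a range of 10 10^-6 cm/s to 90 10^-6 cm/s. The expected step, within the scatter, is a 1.3-fold higher number from compound 3 to compound 4 (0.12 log units; within the scatter).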

Compound 4, apparent permeability: 23 10^-6 cm/s
Beside the measured number, compound 4's estimate is 1.3-fold (0.12 log units) above it; the measured number falls inside the stated range.
By their numbers in this assay, from the lowest: compounds 1, 3 and 4 (each within the scatter of the next); then compound 2.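

In this assay the change on a saturated chain carbon bound to an amine nitrogen, 2-hydroxy-3-methoxyphenyl in place of furan-2-yl, can now be read on its own (no change at the digits printed from compound 3 to compound 4 (within the scatter)), and with cyclohexyl held on the aromatic carbon it leaves the number where it was. At the aromatic carbon, with the 2-hydroxy-3-methoxybenzyl group held, cyclohexyl in place of 4-fluorophenyl gives a large step (a 10-fold lower number from compound 2 to compound 4 (1.01 log units; beyond the scatter)), while cyclohexyl in place of 4-fluorobenzyl gives none (no change at the digits printed from compound 1 to compound 4 (within the scatter)). Among these compounds, then, the large steps all involve the 4-fluorophenyl of compound 2.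

On these data alone, whether the chain position stays as quiet with 4-fluorophenyl on the aromatic carbon remains open, as does what a pyridine ring or a longer chain would do there. The data shown offer no explanation for any of these steps.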